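Swapping a Methylphenyl for a Nitrophenyl Amide

A few compounds are considered here, and "the series" means these few. Any claim that something is new, unique, unknown or untested is made for them only; others in the source may bear on it.

Of the compounds shown here, three sharing one core have been tested in a functional assay on C8166 cells (Homo sapiens) for cytotoxicity, read by MTT assay; a higher number here means that more compound is tolerated, a lower number that less compound is tolerated. Compound 1 `Cc1cccc(C(=O)Nc2cc(Cl)ccc2OCC(=O)Nc2ccc(S(N)(=O)=O)cc2C)c1` gives 52900 nM, compound 2 `Cc1ccc(C(=O)Nc2cc(Cl)ccc2OCC(=O)Nc2ccc(S(N)(=O)=O)cc2C)cc1` gives 54200 nM and compound 3 `Cc1cc(S(N)(=O)=O)ccc1NC(=O)COc1ccc(Cl)cc1NC(=O)c1cccc(F)c1` gives 243000 nM. On these numbers compound 2 sits close to compound 1, and the step of a 1.0-fold higher number from compound 1 to compound 2 (0.01 log units; within the scatter) lies within the scatter, so no order between the two can be read. Compound 3 stands apart: the steps of a 4.6-fold higher number from compound 1 to compound 3 (0.66 log units; beyond the scatter) and a 4.5-fold higher number from compound 2 to compound 3 (0.65 log units; beyond the scatter) are both beyond the scatter, meaning the cells tolerate more of compound 3.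

Compound 4 `Cc1cc(S(N)(=O)=O)ccc1NC(=O)COc1ccc(Cl)cc1NC(=O)c1ccccc1[N+](=O)[O-]` has not yet been measured. It differs from compound 2 in one place: 2-nitrophenyl in place of 4-methylphenyl on a carbonyl carbon. Going by the values given here, the only measured step touching the same group is a 4.5-fold higher number from compound 2 to compound 3 (0.65 log units; beyond the scatter), where a different ring swap on that carbonyl carbon raised the number modestly. Among the compounds with values here, no measured compound here carries a nitro group, so the direction for compound 4 rests on thin ground. A small rise, or no change beyond the scatter, is expected, which gives the estimated step of a 1.5-fold higher number from compound 2 to compound 4 (0.17 log units; within the scatter). Compound 4 is therefore estimated at 80000 nM in this assay, with a likely range from 30000 nM to 250000 nM.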

Compound 4, half-maximal cytotoxic concentration: 54800 nM
For compound 4 the middle estimate is 1.5-fold (0.16 log units) above the measured one, and the stated range covers the measured number.
By their numbers in this assay, from the lowest: compounds 1, 2 and 4 (each within the scatter of the next); then compound 3.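

In this assay, placing 2-nitrophenyl on the carbonyl carbon brings no change that can be read against either methylphenyl ring (a 1.0-fold higher number from compound 2 to compound 4 (0.00 log units; within the scatter) and a 1.0-fold higher number from compound 1 to compound 4 (0.02 log units; within the scatter)). This shows that the position can take a ring group with more heavy atoms, with nitrogen and oxygen among them and with hydrogen-bond acceptors that 4-methylphenyl lacks, while the number stays within the scatter. The earlier compounds shown here also left open whether leaving the methylphenyl rings would in general raise the number, and the new result answers that for this one group: compound 3 remains apart from the nitro compound (a 4.4-fold lower number from compound 3 to compound 4 (0.65 log units; beyond the scatter)), so the rise seen with 3-fluorophenyl is not shared by 2-nitrophenyl.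

The compounds shown cannot separate the effect of the substituent from that of its place on the ring, as fluoro and nitro appear at one ring position each, and a 2-fluorophenyl or 3-nitrophenyl ring would address that. On these data alone, it also remains open how this position responds to an amine or a carboxylic acid on the ring. Nothing measured here explains why 3-fluorophenyl stands apart.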